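The source may report more compounds than this note shows. Statements on the series, on what has been measured and on what is new or still open speak of the compounds shown alone.

Compound 1 `CCOC(=O)c1cc([Se]c2ccccc2C)c2cc(OC)ccc2n1`: 38900 nM
Compound 2 `CCOC(=O)c1cc([Se]c2ccccc2)c2cc(Cl)ccc2n1`: 47100 nM

In a functional assay on SK-MEL-147 cells (Homo sapiens) for cytotoxicity, read by MTT assay, with a stated time of 24 h (a higher number here means that more compound is needed for the effect, a lower number that less compound is needed), compound 2 gives the higher of the two numbers, but compound 1 sits only a small distance away, a gap that lies within the scatter, so no order between the two can be claimed. Compound 3 `CCOC(=O)c1cc([Se]c2ccccc2)c2cc(OC)ccc2n1` has not yet been measured. It differs from compound 2 by methoxy in place of chloro on an aromatic carbon. Among the compounds with values here, no measured pair shows what such a change does here, so no movement beyond the scatter is expected in this assay. Compound 3 is therefore expected to give about 43000 nM, within 20000 nM to 95000 nM, an estimated step of a 1.1-fold lower number from compound 2 to compound 3 (0.04 log units; within the scatter) that stays inside the scatter.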

Compound 3, half-maximal effective concentration: 33000 nM
For compound 3 the middle estimate is 1.3-fold (0.11 log units) above the measured one, and the stated range covers the measured number.
By their numbers in this assay, from the lowest: compounds 3, 1 and 2 (each within the scatter of the next).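

In this assay, methoxy in place of chloro on this aromatic carbon gives a 1.4-fold lower number from compound 2 to compound 3 (0.15 log units; within the scatter). Within the data shown here, this is the first measured sign that the two groups can be exchanged here without a readable shift in the number. Hydrogen in place of methyl on an aromatic carbon gives a 1.2-fold lower number from compound 1 to compound 3 (0.07 log units; within the scatter), so that change also shows no readable shift, and nothing measured here offers an explanation for either result.

On these data alone, whether an amine or a carboxylic acid on the same carbon would move the number beyond the scatter remains open.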